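Naphthalen-1-yl variant of compound 1: cytotoxicity expectation

The source may hold more compounds than are shown below. What is called first, only, known or untested is meant among the compounds shown, and "the series" means these compounds.

Within the data shown here, compound 1 `Cc1cc(S(=O)(=O)/N=C(\N)n2nccc2-c2ccccc2)c(SCc2cccc(Cl)c2)cc1Cl` gives the lowest of the two numbers measured so far in an ADME assay on HaCaT cells (Homo sapiens) for cytotoxicity, read by MTT assay, with a stated time of 72 h (a lower number here means a stronger inhibitor, a higher number a weaker inhibitor), namely 10000 nM. Compound 2 `Cc1cc(-c2ccccc2)n(/C(N)=N/S(=O)(=O)c2cc(C)c(Cl)cc2SCc2cccc(Cl)c2)n1` gives 18000 nM in this assay; the step of a 1.8-fold higher number from compound 1 to compound 2 (0.26 log units; within the scatter) lies within the scatter, so the two values cannot be told apart.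

Compound 3 `Cc1cc(S(=O)(=O)/N=C(\N)n2nccc2-c2ccccc2)c(SCc2cccc3ccccc23)cc1Cl` carries naphthalen-1-yl in place of 3-chlorophenyl on a saturated chain carbon bound to a sulfur. Among the measured compounds shown here, no measured step bears on this exchange: the single step available, from compound 1 to compound 2, concerns a methyl in place of hydrogen on an aromatic carbon of the shared core and leaves the group on the sulfur-bound chain carbon untouched, so it says nothing about size or direction here. For the measured compounds named here, both measured values sit at the weak end of this assay and within the scatter of each other, which is the only anchor for compound 3. The step expected from compound 1 to compound 3 is therefore none beyond the scatter, no change at the digits printed from compound 1 to compound 3 (within the scatter). For compound 3 the estimated value in this assay is 10000 nM, with a range from 3000 nM to 30000 nM.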

Compound 3, half-maximal inhibitory concentration: 11000 nM
Compound 3: the middle estimate sits 1.1-fold (0.04 log units) below what was measured; the range from low to high includes it.
By their numbers in this assay, from the lowest: compounds 1, 3 and 2 (each within the scatter of the next).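

In this assay, the exchange of 3-chlorophenyl for naphthalen-1-yl on a saturated chain carbon bound to a sulfur gives a 1.1-fold higher number from compound 1 to compound 3 (0.04 log units; within the scatter), so this change at this position leaves compound 1 and compound 3 indistinguishable, whereas the earlier step concerned only a methyl on the shared core. The exchange removes the chlorine and adds a second six-membered aromatic ring of carbon only, taking the group from 7 to 10 heavy atoms, and these two differences arrive together, so the result cannot assign any contribution to either one alone. Nothing among the data shown offers an explanation for this outcome.

As far as these compounds go, whether any group on this chain carbon can move the number in this assay beyond the scatter remains open, since a single exchange between two aromatic groups is a narrow test of the position. An amine or a carboxylic acid in place of the aromatic group, or a longer chain between the sulfur and the ring, would show whether the position stays equally unresponsive to groups of a different kind.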